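Replacing Methoxycarbonyl with Phenyl on a Carbonyl Carbon

The compounds below may be only part of what the source reports. "The series", "measured", "known", "first", "only" and "open" are said of these compounds alone.

Among the compounds with values here, in a functional assay on Vero cells (Chlorocebus sabaeus) for inhibition (on this read-out higher numbers stand for weaker inhibition and lower numbers for stronger inhibition), compound 2 (`COC(=O)C(=O)Nc1cccc(C(=O)/C=C/c2ccc(O)c(OC)c2)c1`) gives 3.55 ug/mL, the lower of the two numbers measured so far. Compound 1 (`COc1cc(/C=C/C(=O)c2cccc(NC(=O)c3ccc(Cl)cc3Cl)c2)ccc1O`) gives 27.2 ug/mL. Compound 3 (`COc1cc(/C=C/C(=O)c2cccc(NC(=O)c3ccccc3)c2)ccc1O`) has not yet been measured. It differs from compound 2 as follows: phenyl in place of methoxycarbonyl on a carbonyl carbon. In words, this is phenyl in place of methoxycarbonyl on a carbonyl carbon.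

Within the data shown here, only one measured step bears on this change: a 7.7-fold lower number from compound 1 to compound 2 (0.88 log units; beyond the scatter). There, methoxycarbonyl replaced 2,4-dichlorophenyl at the same kind of place, and the step lay beyond the scatter. Compound 3 goes back to an aromatic ring on that carbonyl carbon, though one without the chlorines of compound 1. Among the measured compounds shown here, no compound carrying plain phenyl has a measured value, so this single step is a limited guide. Most of that step is expected to reverse, which points to a higher number in this assay. The expected change is a 5.1-fold higher number from compound 2 to compound 3 (0.71 log units; beyond the scatter). Compound 3 is estimated at 18 ug/mL, with an expected range of 7 ug/mL to 45 ug/mL.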

Compound 3, half-maximal inhibitory concentration: 3.47 ug/mL
Beside the measured number, compound 3's estimate is 5.2-fold (0.71 log units) above it; measured number outside the range, below it.
By their numbers in this assay, from the lowest: compounds 3 and 2 (each within the scatter of the next); then compound 1.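

In this assay, the step of a 1.0-fold lower number from compound 2 to compound 3 (0.01 log units; within the scatter) shows that on this carbonyl carbon, whose other neighbour is the amide-type nitrogen, phenyl and methoxycarbonyl cannot be told apart, even though one is a six-membered aromatic ring and the other has no ring and carries two hydrogen-bond acceptors. With a 7.8-fold lower number from compound 1 to compound 3 (0.89 log units; beyond the scatter) for phenyl in place of 2,4-dichlorophenyl, an aromatic ring at this place no longer goes with the higher number, as compound 1 alone had suggested; among these three compounds, that number goes with 2,4-dichlorophenyl and not with the presence of a ring. No measurement given here accounts for the match between phenyl and methoxycarbonyl or for the separate standing of 2,4-dichlorophenyl.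

The compounds shown leave open whether a phenyl with a single chlorine would read like phenyl or like 2,4-dichlorophenyl, so the two chlorines cannot yet be separated. They also leave open whether a carboxylic acid in place of methoxycarbonyl, or a longer alkyl chain on this carbonyl carbon, would keep the number of compound 2 and compound 3.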